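This account rests on a few compounds, and the source may have more. Where it says the series, first, only, none or still open, it means among the compounds named here.

Measured so far in a functional assay on MOLT-4F cells (Homo sapiens) for antiproliferative activity; a higher number here means a weaker inhibitor of growth, a lower number a stronger inhibitor of growth:
- compound 1 `COCCCCCCCCCCCCCCC/C=C1\CC(CO)(COC(=O)C(C)(C)C)OC1=O`: 0.498 ug/mL
- compound 2 `COCCCCCCCCCCC/C=C1\CC(CO)(COC(=O)C(C)(C)C)OC1=O`: 2.38 ug/mL
- compound 3 `CCCCCOCCCCCCC/C=C1\CC(CO)(COC(=O)C(C)(C)C)OC1=O`: 1.03 ug/mL

Compound 2, at 2.38 ug/mL, has the highest number of the three and is the weakest growth inhibitor among them. Its nearest neighbour is reached by the step of a 2.3-fold lower number from compound 2 to compound 3 (0.36 log units; beyond the scatter). Compound 1, at 0.498 ug/mL, lies furthest away.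

Next is compound 4 `CC(=O)OCCCCCCCCCCCCCCC/C=C1\CC(CO)(COC(=O)C(C)(C)C)OC1=O`, not yet measured. The change is 4-acetoxybutyl in place of methoxy on a saturated chain carbon, ten or more bonds along the chain from a double-bonded chain carbon. In words, 4-acetoxybutyl stands in place of methoxy on a saturated chain carbon.

Going by the values given here, the closest precedent is the exchange of the same methoxy and 4-methoxybutyl at that place, a 4.8-fold higher number from compound 1 to compound 2 (0.68 log units; beyond the scatter). Read in reverse, it shows the 4-methoxybutyl compound with the lower number. The pentyloxy change, a 2.3-fold lower number from compound 2 to compound 3 (0.36 log units; beyond the scatter), also goes toward a lower number, and a 2.1-fold higher number from compound 1 to compound 3 (0.32 log units; beyond the scatter) places that compound between the other two. Among the compounds with values here, no compound with an acetoxy group has been measured, so this precedent is only partial.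

A modest move toward a lower number is expected, close in size to the reverse of the first step. The expected step is a 3.4-fold lower number from compound 2 to compound 4 (0.53 log units; beyond the scatter). For compound 4 the estimate is 0.7 ug/mL, with an expected range of 0.25 ug/mL to 2 ug/mL.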

Compound 4, concentration for 50% growth inhibition: 1.55 ug/mL
Compound 4: middle estimate off by 2.2-fold (0.35 log units), on the low side; low and high end bracket the measured number.
By their numbers in this assay, from the lowest: compound 1; then compounds 3, 4 and 2 (each within the scatter of the next, the first and the last beyond it).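

Holding the chain of compound 1 fixed, acetyl in place of methyl on an oxygen on a saturated carbon costs activity in this assay (a 3.1-fold higher number from compound 1 to compound 4 (0.49 log units; beyond the scatter)), so the group at the chain end matters and not only the length of the chain. The acetoxy-ended chain of compound 4 cannot be told apart from the shorter methoxy-ended chain of compound 2, with 4-acetoxybutyl in place of methoxy on a saturated chain carbon (a 1.5-fold lower number from compound 2 to compound 4 (0.19 log units; within the scatter)), or from the pentyloxy chain of compound 3, with 8-acetoxyoctyl in place of pentyloxy (a 1.5-fold higher number from compound 3 to compound 4 (0.18 log units; within the scatter)). Compound 1 therefore remains the strongest growth inhibitor of the four, and the benefit of 4-methoxybutyl over methoxy does not carry over to 4-acetoxybutyl.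

Nothing available explains the difference between the methoxy and acetoxy chain ends. From the compounds shown here alone, whether a terminal hydroxyl, amine or carboxylic acid on the same chain would track the methoxy end or the acetoxy end stays open, as does the response of either end to a longer chain.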